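The compounds below may be only part of what the source reports. "The series", "measured", "known", "first", "only" and "open" are said of these compounds alone.

In a functional assay on the whole organism with Rattus norvegicus as the target (a higher number here means that more compound is needed for the effect, a lower number that less compound is needed), three compounds have been measured so far. Compound 1 `Nc1nc2ccc(C3CCCCC3)cc2s1` gives only a limit of the assay, > 10 mg/kg. Compound 2 `Nc1nc2cc(OC(F)(F)F)ccc2s1` also gives only a limit, > 10 mg/kg. Compound 3 `Cn1c(=N)sc2cc(OC(F)(F)F)ccc21` gives 5 mg/kg, which makes it the only one of the three with an actual number.

Compound 4 `N#CCn1c(=N)sc2cc(OC(F)(F)F)ccc21` differs from compound 3 by a single change, cyano in place of hydrogen on a saturated chain carbon bound to an aromatic nitrogen. The same difference reads as methyl to cyanomethyl. Going by the values given here, no measured pair of compounds shows the effect of this change, so the expectation rests on compound 3 at 5 mg/kg and on nothing closer. No step beyond the usual scatter is expected in this assay, in either direction. The estimated step is a 1.2-fold higher number from compound 3 to compound 4 (0.08 log units; within the scatter), and the result could still come back as a limit alone. For compound 4 the expected value is 6 mg/kg, with an estimated range from 2 mg/kg to 18 mg/kg.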

Compound 4, dose for half-maximal effect: 3.5 mg/kg
Compound 4: the middle estimate sits 1.7-fold (0.23 log units) above what was measured; measured number inside the range.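

Before compound 4, the saturated chain carbon bound to an aromatic nitrogen had been seen only as methyl, so compound 3 alone could not show whether that place accepts anything else. Cyano in place of hydrogen there gives a 1.4-fold lower number from compound 3 to compound 4 (0.15 log units; within the scatter) in this assay, so the methyl to cyanomethyl difference cannot be told from repeat measurement and the two compounds read as equal. Like compound 3, compound 4 returns an actual number rather than a limit, which sets both apart from the other compounds: the limit of > 10 mg/kg in this assay, at which 2 of the 4 values shown sit.

This single step does not show whether the nitrile itself matters or whether other groups at this place would read the same. A longer chain, an amine or a carboxylic acid in place of the cyano remains an open case.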